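This account rests on a few compounds, and the source may have more. Where it says the series, first, only, none or still open, it means among the compounds named here.

The compounds measured so far, with their values:

compound 1, `CC(C)(C)c1ccc(/C=N/NC(N)=S)cc1`: > 100%
compound 2, `Cc1cccc(/C=N/NC(N)=S)c1`: > 100%
compound 3, `Cc1ccccc1/C=N/NC(N)=S`: > 100%

All three were tested in a functional assay on B16 cells (Mus musculus) for inhibition, tested at 10 uM; on this read-out lower numbers stand for less inhibition and higher numbers for more inhibition at the one concentration tested (going by the name of the read-out). The value of compound 1 is a limit of the assay, not a number. The same holds for compound 2, whose value is also a limit. Compound 3 too gives only a limit, > 100%, so its place among the numbers shown cannot be ranked finer than that: it sits where every other measured compound sits, as the limit of > 100% in this assay, at which 3 of the 3 values shown sit, shows. For the measured compounds named here, no step between two measured compounds is known, so nothing about how a single change shifts this read-out can be drawn from them.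

The next compound, compound 4, `NC(=S)N/N=C/c1ccccc1O`, differs from compound 3 by hydroxy in place of methyl on an aromatic carbon. With every measured compound at the same limit, no step beyond the scatter can be predicted in this assay in either direction. Compound 4 is therefore expected to land at roughly 100%, within the range 75% to 100%. The step this estimate implies, a number no higher from compound 3 to compound 4 (the limit leaves the size open), is expected to stay within the scatter.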

Compound 4, a percentage reported as inhibition, at one concentration (the size of the read-out at that concentration, not a potency): 24%
For compound 4 the middle estimate is 76 percentage points above the measured one; measured number below the stated range.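

In this assay, hydroxy in place of methyl on an aromatic carbon, ortho to a group of 6 heavy atoms, gives a number at least 76 percentage points lower from compound 3 to compound 4 (beyond the scatter). For the compounds shown here, this is the first measured step, and it shows that the read-out is sensitive to what sits at this place, even when one heavy atom is exchanged for one other, with a hydrogen-bond donor and acceptor entering. Compound 1, compound 2 and compound 3 share a limit of the assay, so only compound 4 gives a value that can be read as a number: the limit of > 100% in this assay, at which 3 of the 4 values shown sit.

A single exchange cannot show which difference between methyl and hydroxy matters. On these data alone, it remains open whether an amine or a methoxy group at this place would follow hydroxy or methyl, and whether hydroxy on another aromatic carbon would give a similar result.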